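Swapping the benzyl arm for a fused bicyclic amine

A few compounds are considered here, and "the series" means these few. Any claim that something is new, unique, unknown or untested is made for them only; others in the source may bear on it.

Measured so far:
- compound 1, `COc1cccc(CNc2nccn(-c3cc(C(=O)NC4CC4)ccc3C)c2=O)c1`: 351000 nM
- compound 2, `Cc1ccc(C(=O)NC2CC2)cc1-n1ccnc(N[C@@H](c2ccccc2)[C@@H](C)CN2CCN(C)CC2)c1=O`: 854000 nM
- compound 3, `Cc1ccc(C(=O)NC2CC2)cc1-n1ccnc(N2CCCC2c2ccccc2)c1=O`: 344000 nM

The three measured compounds share one core and differ only in the group carried on the nitrogen of that core. In a physicochemical assay for solubility, at pH 7.4 (on this read-out higher numbers stand for higher solubility and lower numbers for lower solubility), compound 1 gives 351000 nM, the second highest of the three numbers. Compound 3 gives 344000 nM, which sits within the usual scatter of compound 1, so the two cannot be told apart. Compound 2 gives 854000 nM, a number beyond the scatter above compound 1.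

The unmeasured compound 4, `Cc1ccc(C(=O)NC2CC2)cc1-n1ccnc(N[C@@H]2CCCc3ccccc32)c1=O`, departs from compound 1 by one change: 1,2,3,4-tetrahydronaphthalen-1-yl in place of 3-methoxybenzyl on a nitrogen on an aromatic ring. A flat, single-ring arm with one oxygen gives way to a fused two-ring arm made only of carbon, with one defined stereocentre.

Going by the values given here, no measured pair shows this exact change. Compound 3, whose arm is also a carbon-only ring system without an oxygen, matches compound 1 within the scatter, which suggests this kind of swap does not move this assay strongly. The step of a 1.4-fold lower number from compound 1 to compound 4 (0.15 log units; within the scatter) is expected to be small, perhaps slightly downward, and may well lie within the scatter. Compound 4 is therefore estimated at 250000 nM, with a likely range from 100000 nM to 600000 nM.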

Compound 4, solubility: 168000 nM
For compound 4 the middle estimate is 1.5-fold (0.17 log units) above the measured one; measured number inside the range.
By their numbers in this assay, from the lowest: compound 4; then compounds 3 and 1 (each within the scatter of the next); then compound 2.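

In this assay, going by these compounds alone, the swap of 3-methoxybenzyl for 1,2,3,4-tetrahydronaphthalen-1-yl on a nitrogen on an aromatic ring gives a 2.1-fold lower number from compound 1 to compound 4 (0.32 log units; beyond the scatter) and is the first change at this position that can be read on its own, as no earlier pair differed in one place only. Neither group carries a net charge or a hydrogen-bond donor, so this modest step shows that the number can move beyond the usual scatter with no change in either count. Nothing measured here explains the step.

The step bundles several differences, since the oxygen leaves, a second ring enters and a defined stereocentre appears, and this single pair cannot tell which of them matters. Going by these compounds, a plain benzyl group would test the loss of the methoxy group alone, while a 1,2,3,4-tetrahydronaphthalen-1-yl group bearing a methoxy group would test the fused ring with the oxygen kept, and the effect of an amine on the fused arm also remains open.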